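The compounds below may be only part of what the source reports. "The series", "measured", "known", "first", "only" and "open" are said of these compounds alone.

The measured compounds in a functional assay on PC-3 cells (Homo sapiens) for inhibition; a higher number here means a weaker inhibitor, a lower number a stronger inhibitor:
compound 1 `Cc1c(C(=O)N/N=C\c2c(O)cccc2F)oc2cccc(O)c12` gives 8050 nM;
compound 2 `Cc1c(C(=O)N/N=C\c2cccc(O)c2O)oc2cccc(O)c12` gives 12200 nM;
compound 3 `Cc1c(C(=O)N/N=C\c2cccc(O)c2)oc2cccc(O)c12` gives 17600 nM.

Compound 2 stands with the second highest of the three numbers, and its distances to the other two remain within the scatter: a 1.5-fold higher number from compound 1 to compound 2 (0.18 log units; within the scatter) and a 1.4-fold higher number from compound 2 to compound 3 (0.16 log units; within the scatter). Compound 4 `Cc1c(C(=O)N/N=C\c2ccc(O)c(O)c2O)oc2cccc(O)c12` differs from compound 2 by hydroxy in place of hydrogen on an aromatic carbon. Going by the values given here, the step that bears most directly on this change is the removal of a hydroxy from an aromatic carbon between compound 2 and compound 3, which stayed within the scatter; the only step beyond it, a 2.2-fold higher number from compound 1 to compound 3 (0.34 log units; beyond the scatter), was modest. Adding a hydroxy here is therefore expected to give no step beyond the scatter in this assay, the expected step being a 1.1-fold lower number from compound 2 to compound 4 (0.04 log units; within the scatter). The estimate for compound 4 is 11000 nM, with a range from 5000 nM to 25000 nM.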

Compound 4, half-maximal inhibitory concentration: >= 40000 nM
Compound 4: no number, only a limit; the forecaster's own chance of this, stated with the estimate: 5%; middle value at least 3.6-fold (0.56 log units) from the limit.
By their numbers in this assay, from the lowest: compounds 1, 2 and 3 (each within the scatter of the next, the first and the last beyond it). At a limit, above all of these: compound 4.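

In this assay, hydroxy in place of hydrogen at this position, ortho to a hydroxy group and para to a large group, gives an at least 3.2-fold higher number from compound 2 to compound 4 (0.51 log units; beyond the scatter). Going by these compounds alone, the same ring had so far given no step larger than a 2.2-fold higher number from compound 1 to compound 3 (0.34 log units; beyond the scatter), so this position responds to a change more than the earlier compounds suggested. The value of compound 4 is a limit and not a number, so the step has no upper bound: the limit of >= 40000 nM in this assay, at which 1 of the 4 values shown sits.

On these data alone, whether a methoxy or an amine at this position would behave like hydroxy remains open. So does whether this hydroxy has the same effect without the other hydroxy groups on the ring.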